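This account rests on a few compounds, and the source may have more. Where it says the series, first, only, none or still open, it means among the compounds named here.

Measured compounds:
Compound 1 `Cc1ccc(NC(=O)CC(CCC(=O)O)c2nnc(CCCC(C)C)n2C2CC2)c(C)c1`, 91%
Compound 2 `Cc1ccc(NC(=O)CC(CCC(N)=O)c2nnc(CCCC(C)C)n2C2CC2)c(C)c1`, 44%
Compound 3 `Cc1ccc(NC(=O)C[C@H](CCC(=O)O)c2noc(-c3ccc(CC(C)C)cc3)c2C2CC2)c(Cl)c1`, 80%

All three were run in an ADME assay on microsomes from liver (Homo sapiens) for metabolic stability, with a stated time of 60 min; on this read-out higher numbers stand for a more stable compound and lower numbers for a less stable compound. Compound 3 stands second highest of the three. Compound 1 lies higher than compound 3 by a gap beyond the scatter, and compound 2 lies well below compound 3, again beyond the scatter. Among the compounds with values here, the only step measured between directly comparable structures is a number 47 percentage points lower from compound 1 to compound 2 (beyond the scatter).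

Compound 4 `Cc1ccc(NC(=O)C[C@H](CCC(=O)O)c2noc(-c3cc(C(F)(F)CC(C)C)on3)c2C2CC2)c(Cl)c1` is not yet measured. It differs from compound 3 in one place: 5-(1,1-difluoro-3-methylbutyl)-1,2-oxazol-3-yl in place of 4-isobutylphenyl on an aromatic carbon. Within the data shown here, no measured step bears on this kind of change. Among the measured compounds shown here, the one step known, from compound 1 to compound 2, concerns an amino in place of hydroxy on a carbonyl carbon, which sits on a different part of the molecule and is a different kind of exchange; it gives no guide to the size or direction of the step from compound 3 to compound 4 in this assay. The expectation therefore rests on compound 3 alone, with a wide range on either side to cover the lack of a relevant precedent.

Compound 4 is expected to give 70%, between 45% and 90%. This corresponds to an expected a number 10 percentage points lower from compound 3 to compound 4 (within the scatter).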

Compound 4, percent of the compound remaining: 78%
Compound 4: the middle estimate sits 8 percentage points below what was measured; measured number inside the range.
By their numbers in this assay, from the lowest: compound 2; then compounds 4 and 3 (each within the scatter of the next); then compound 1.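

In this assay, the exchange of 4-isobutylphenyl for 5-(1,1-difluoro-3-methylbutyl)-1,2-oxazol-3-yl, on the aromatic carbon next to the ring oxygen, gives a number 2 percentage points lower from compound 3 to compound 4 (within the scatter). Within the data shown here, this is the first reading at this position: a six-membered aromatic ring of carbon only can give way to a five-membered aromatic ring with 2 hetero atoms, with 2 fluorine atoms and 2 hydrogen-bond acceptors entering, and the read-out stays within the scatter, whereas the only earlier step concerned a carbonyl carbon elsewhere in the molecule. No measurement shown accounts for this result.

Ring and chain differ together in this exchange, so the compounds shown leave open what each contributes; a plain 3-methylbutyl chain on the same five-membered ring, or 1,1-difluoro-3-methylbutyl on the phenyl ring, would separate the two. Also open, going by these compounds, is whether the exchange would still read this way with a primary amide in place of the carboxylic acid, the change that gave a number 47 percentage points lower from compound 1 to compound 2 (beyond the scatter) on another core.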